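Substitution on the fused ring of the sulfonamide series

This account rests on a few compounds, and the source may have more. Where it says the series, first, only, none or still open, it means among the compounds named here.

Measured so far:
compound 1, `Cc1noc(NS(=O)(=O)c2cccc3c(NCCCCCc4ccccc4)cccc23)c1C`, 3050 nM
compound 2, `Cc1noc(NS(=O)(=O)c2cccc3c(NCc4ccccc4)cccc23)c1C`, 590 nM
compound 3, `Cc1noc(NS(=O)(=O)c2cccc3ccccc23)c1C`, 20000 nM

The three compounds share one core and differ only at a single aromatic carbon of the fused ring pair. In an assay on VSM-A10 cells for antagonist activity at Endothelin-1 receptor (Rattus norvegicus) (a lower number here means a stronger inhibitor, a higher number a weaker inhibitor), compound 3 gives 20000 nM, the highest number of the three. Its nearest neighbour is compound 1, and the gap to compound 2 is the largest in the set.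

The unmeasured compound 4, `Cc1noc(NS(=O)(=O)c2cccc3c(N/C(S)=N/c4ccccc4)cccc23)c1C`, carries a group of 10 heavy atoms (7 carbon, 2 nitrogen, 1 sulfur; one six-membered aromatic ring of carbon only) in place of a hydrogen atom, on an aromatic carbon. Among the compounds with values here, the one step that bears directly on this is a 34-fold higher number from compound 2 to compound 3 (1.53 log units; beyond the scatter), which shows that removing the benzylamino group from that carbon costs a large amount. The step of a 5.2-fold lower number from compound 1 to compound 2 (0.71 log units; beyond the scatter) adds that the size of the group at this position matters, a longer chain bringing a modestly higher number than the simple benzyl. The group entering in compound 4 is larger than benzylamino and places the phenyl further out, so a drop in the number is expected, but probably not the full amount recovered by compound 2.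

For compound 4 the expected step is a 13-fold lower number from compound 3 to compound 4 (1.12 log units; beyond the scatter). The estimated value for compound 4 is 1500 nM, with a range from 300 nM to 8000 nM.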

Compound 4, half-maximal inhibitory concentration: 150 nM
The estimate for compound 4 lay 10-fold (1.00 log units) above the measured number, outside the stated range (below it).
By their numbers in this assay, from the lowest: compound 4; then compound 2; then compound 1; then compound 3.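

At this aromatic carbon in this assay, the sulfur-bearing group gives a 130-fold lower number from compound 3 to compound 4 (2.12 log units; beyond the scatter) and leaves compound 4 with the lowest number of the four, so the position accepts more than the benzylamino group of compound 2 had indicated. On the nitrogen on the aromatic ring, the change gives a 3.9-fold lower number from compound 2 to compound 4 (0.59 log units; beyond the scatter) and also a 20-fold lower number from compound 1 to compound 4 (1.31 log units; beyond the scatter); the group in compound 4 is larger than the one in compound 2 and smaller than the one in compound 1, yet its number is lower than both, so among these three compounds the number does not follow group size alone. No supporting measurement bears on why this group outperforms the others.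

The compounds shown do not separate the contribution of the sulfur from that of the added nitrogen or of the phenyl ring, so an oxygen in place of the sulfur, or a methyl in place of the phenyl, would each test one part of the group. Also open, on these data alone, is how a chloro or methoxy group on that phenyl ring would shift the number.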